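The source may hold more compounds than are shown below. What is called first, only, known or untested is meant among the compounds shown, and "the series" means these compounds.

For the measured compounds named here, compound 1 `CCNC(=O)N1CCN(C(=S)SCc2cn(Cc3ccccc3F)nn2)CC1` stands at the lower of the two numbers measured so far: in a functional assay on MCF7 cells (Homo sapiens) for cytotoxicity, read by MTT assay, with a stated time of 72 h (on this read-out lower numbers stand for stronger inhibition and higher numbers for weaker inhibition), compound 1 gives 5760 nM, while compound 2 `CC(C)(C)NC(=O)N1CCN(C(=S)SCc2cn(Cc3ccccc3F)nn2)CC1` gives 18800 nM. Going by the values given here, the one measured step, a 3.3-fold higher number from compound 1 to compound 2 (0.51 log units; beyond the scatter), concerns a different part of the molecule. Compound 3 `CCNC(=O)N1CCN(C(=S)SCc2cn(Cc3ccc(F)cc3)nn2)CC1` differs from compound 1 by 4-fluorophenyl in place of 2-fluorophenyl on a saturated chain carbon bound to an aromatic nitrogen. No measured step touches this change, so the data give no reason to expect movement, and the expected step of a 1.0-fold higher number from compound 1 to compound 3 (0.00 log units; within the scatter) lies within the usual scatter. The estimate for compound 3 in this assay is 5800 nM, within 2500 nM to 13500 nM.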

Compound 3, half-maximal inhibitory concentration: 3660 nM
Compound 3: the middle estimate sits 1.6-fold (0.20 log units) above what was measured; measured number inside the range.
By their numbers in this assay, from the lowest: compounds 3 and 1 (each within the scatter of the next); then compound 2.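

Placing 4-fluorophenyl in place of 2-fluorophenyl on a saturated chain carbon bound to an aromatic nitrogen gives a 1.6-fold lower number from compound 1 to compound 3 (0.20 log units; within the scatter) in this assay. For the compounds shown here, for this pair, the two fluorophenyl groups cannot be told apart on this read-out, a first look at a position that the tert-butyl and ethyl comparison did not touch. No supporting evidence bears on this result.

As far as these compounds go, what stays open is whether a larger change here would register: plain phenyl or 4-methoxyphenyl could show how much this group matters.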